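The source may hold more compounds than are shown below. What is called first, only, known or untested is meant among the compounds shown, and "the series" means these compounds.

Of the compounds shown here, two have been measured in an assay on isolated protein for inhibition of histone deacetylase 8 (Homo sapiens), read by fluorescence, with a stated time of 20 min; a higher number here means a weaker inhibitor, a lower number a stronger inhibitor. Compound 1, `Nc1ccccc1NC(=O)c1ccc(CNCc2nc(-c3ccc(C(F)(F)F)cc3)no2)cc1`, carries an aminoanilide end and a trifluoromethyl-bearing aryl on the other side of the shared core. In this assay compound 1 gives > 10000 nM, which is a limit of the assay and not a number. Compound 1 therefore sits at the limit of > 10000 nM in this assay, at which 1 of the 2 values shown sits. Compound 2, `O=C(NO)c1ccc(CNCc2nc(-c3ccccc3)no2)cc1`, carries a hydroxamic acid in place of the aminoanilide and an unsubstituted phenyl. In this assay, for the measured compounds named here, compound 2 gives 200 nM, the only actual number among the values shown, so compound 2 is the sole point from which to reason.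

Compound 3, `O=C(NO)c1ccc(CNCc2nc(-c3ccc(C(F)(F)F)cc3)no2)cc1`, has not yet been measured. It keeps the hydroxamic acid of compound 2 and differs from it only by trifluoromethyl in place of hydrogen on an aromatic carbon. Going by the values given here, no measured pair in this set isolates that change, and nothing here attributes any effect to the trifluoromethyl group on its own. The step from compound 2 to compound 3 is therefore expected to be modest, within or only a little beyond the usual scatter, as a 1.3-fold higher number from compound 2 to compound 3 (0.10 log units; within the scatter), with no strong lean in either direction. In this assay compound 3 is accordingly expected to give 250 nM, within a range of 80 nM to 800 nM.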

Compound 3, half-maximal inhibitory concentration: 1360 nM
For compound 3 the middle estimate is 5.4-fold (0.74 log units) below the measured one, and the stated range ends below it.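

In this assay, trifluoromethyl in place of hydrogen on an aromatic carbon, para to a large group, is now isolated with the hydroxamic acid held fixed, and it gives a 6.8-fold higher number from compound 2 to compound 3 (0.83 log units; beyond the scatter), so compound 3 is the weaker inhibitor and this position is shown not to be indifferent to the change. For the compounds shown here, with trifluoromethyl now held fixed as well, the other end of the molecule can also be read for the first time: hydroxy in place of 2-aminophenyl on an amide-type nitrogen gives an at least 7.3-fold lower number from compound 1 to compound 3 (0.86 log units; beyond the scatter), so inhibition in this pair is seen only with the hydroxamic acid end. The value of compound 1 in that step is a limit of the assay and not a number: the limit of > 10000 nM in this assay, at which 1 of the 3 values shown sits.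

Going by these compounds, with only trifluoromethyl set against hydrogen here, it remains open whether a fluorine, a methyl or a methoxy group at the same place would give a smaller step or none. On these data alone, it also remains open whether the step seen with the hydroxamic acid end would carry over to the aminoanilide end.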